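The compounds below may be only part of what the source reports. "The series", "measured", "known", "first", "only" and "open" are said of these compounds alone.

Two members of the series have been run in a functional assay on SK-OV-3 cells (Homo sapiens) for antiproliferative activity, read by MTT assay, with a stated time of 72 h; a lower number here means a stronger inhibitor, a higher number a weaker inhibitor: compound 1 `CC(C)(C)OC(=O)NCc1ccc(NC(=O)CCc2cccc3c2B(O)OC3)cc1` and compound 2 `O=C(CCc1cccc2c1B(O)OC2)Nc1cccc(-c2ccccc2)c1`. In this assay, among the compounds with values here, compound 1 gives 2000 nM, while compound 2 gives 250 nM, the lowest of the two numbers measured so far; the gap between compound 2 and its nearest neighbour, compound 1, lies beyond the usual scatter. Compound 3 `O=C(CCc1cccc2c1B(O)OC2)Nc1cccc(-c2ccc(C(F)(F)F)cc2)c1` has not yet been measured. The change from compound 2 to compound 3 is trifluoromethyl in place of hydrogen on an aromatic carbon. Within the data shown here, no measured pair shows this change, so there is no direct precedent for its size. The expected step from compound 2 to compound 3 is small, a 1.3-fold lower number from compound 2 to compound 3 (0.10 log units; within the scatter), and not clearly beyond the scatter in either direction. Because compound 2 gives 250 nM, compound 3 is estimated at 200 nM, with a range from 60 nM to 700 nM.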

Compound 3, half-maximal inhibitory concentration: 500 nM
Beside the measured number, compound 3's estimate is 2.5-fold (0.40 log units) below it, within the range that was stated.
By their numbers in this assay, from the lowest: compounds 2 and 3 (each within the scatter of the next); then compound 1.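

In this assay, within the data shown here, the change from phenyl to 4-(trifluoromethyl)phenyl gives a 2.0-fold higher number from compound 2 to compound 3 (0.30 log units; within the scatter) and is the first reading of any substituent at this position, on an aromatic carbon para to a large group. Four heavy atoms enter there, yet compounds 2 and 3 cannot be told apart in this assay, so trifluoromethyl at this carbon is tolerated at the level of the scatter. No measurement at hand bears on why this step reads as it does.

On these data alone, a single substituent gives no trend, so it remains open whether an amine, a carboxylic acid or a methoxy group on the same carbon would also read within the scatter of compound 2. Also open, as far as these compounds go, is whether trifluoromethyl would read the same on other aromatic carbons of this ring.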